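Fluoro to Chloro on a Shared Amidine Scaffold

The compounds below may be only part of what the source reports. "The series", "measured", "known", "first", "only" and "open" are said of these compounds alone.

Among the compounds with values here, compound 2 `N=C(N)c1ccc(-c2ccc(-c3ccc(F)cc3)o2)o1` holds the lower of the two numbers measured so far: in a functional assay on SK-MEL-2 cells (Homo sapiens) for inhibition, read by sulforhodamine B assay, with a stated time of 48 h (a higher number here means a weaker inhibitor of growth, a lower number a stronger inhibitor of growth), compound 2 gives 1760 nM. Its nearest neighbour, compound 1 `N=C(N)c1ccc(-c2ccc(-c3cncc4ccccc34)s2)s1`, gives 2000 nM in this assay, a gap that lies within the scatter. Compound 3 `N=C(N)c1ccc(-c2ccc(-c3ccc(Cl)cc3)o2)o1` has not been measured; it differs from compound 2 by chloro in place of fluoro on an aromatic carbon. Within the data shown here, no measured pair shows what such a change does here, so the expected step in this assay is small, in either direction, and probably not beyond the scatter. For compound 3 the estimated value in this assay is 1400 nM, with a range from 550 nM to 3500 nM. This estimate corresponds to an expected step of a 1.3-fold lower number from compound 2 to compound 3 (0.10 log units; within the scatter).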

Compound 3, concentration for 50% growth inhibition: 2080 nM
Beside the measured number, compound 3's estimate is 1.5-fold (0.17 log units) below it; the measured number falls inside the stated range.
By their numbers in this assay, from the lowest: compounds 2, 1 and 3 (each within the scatter of the next).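

Within the data shown here, the first pair here that differs in one place gives, in this assay, a 1.2-fold higher number from compound 2 to compound 3 (0.07 log units; within the scatter). At this carbon, para to a large group, fluoro and chloro therefore cannot be told apart by this read-out. Nothing at hand explains this result.

Still open, going by these compounds, is whether a group of another kind on the same carbon, such as an amine, a carboxylic acid or a methoxy group, would give a number clearly apart from these. Also open, on these data alone, is what plain hydrogen at this carbon would give.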